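Replacing fluoro with trifluoromethyl in compound 3

This account rests on a few compounds, and the source may have more. Where it says the series, first, only, none or still open, it means among the compounds named here.

In a functional assay on NCI-H460 cells (Homo sapiens) for inhibition, read by MTT assay, with a stated time of 72 h (on this read-out higher numbers stand for weaker inhibition and lower numbers for stronger inhibition), compound 1 (`COc1cc(NC(C)CCCNC(=O)NNC(=O)Nc2ccc(Cl)cc2)c2ncccc2c1`) gives 63000 nM. In the same test, compound 2 (`COc1cc(NC(C)CCCNC(=O)NNC(=O)Nc2cccc(F)c2)c2ncccc2c1`) gives 50000 nM. Within the data shown here, these are the only two numbers measured so far, and they lie within the usual scatter of each other, so compound 2 cannot be separated from compound 1.

Compound 3 (`COc1cc(NC(C)CCCNC(=O)NNC(=O)Nc2cccc(C(F)(F)F)c2)c2ncccc2c1`) keeps the whole of compound 2 except for one group: trifluoromethyl in place of fluoro on an aromatic carbon. Trifluoromethyl takes the place of fluoro on an aromatic carbon, meta to a large group.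

Among the measured compounds shown here, the one measured step that bears on this change is a 1.3-fold lower number from compound 1 to compound 2 (0.10 log units; within the scatter), seen when 3-fluorophenyl took the place of 4-chlorophenyl on an amide-type nitrogen. That step stayed within the scatter, although it does not involve trifluoromethyl, which has not yet been measured on this scaffold. No step beyond the scatter is therefore expected in this assay, and the data give no firm direction. The expected change is a 1.3-fold lower number from compound 2 to compound 3 (0.10 log units; within the scatter). For compound 3 the estimated value is 40000 nM, with an expected range from 15000 nM to 90000 nM.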

Compound 3, half-maximal inhibitory concentration: 20000 nM
Beside the measured number, compound 3's estimate is 2.0-fold (0.30 log units) above it; the range from low to high includes it.
By their numbers in this assay, from the lowest: compound 3; then compounds 2 and 1 (each within the scatter of the next).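

In this assay, among these compounds, trifluoromethyl in place of fluoro on an aromatic carbon, meta to a large group, gives a 2.5-fold lower number from compound 2 to compound 3 (0.40 log units; beyond the scatter) and is the first step to lie beyond the scatter, which shows that the group at this position can move the number, although only modestly. The change of 3-(trifluoromethyl)phenyl for 4-chlorophenyl on the amide-type nitrogen gives a 3.2-fold lower number from compound 1 to compound 3 (0.50 log units; beyond the scatter) and is also modest, so compound 3 now stands apart from both earlier compounds, which could not be separated from each other. No measurement offered here accounts for either step.

From the compounds shown here alone, whether a nitrile, a methoxy group or a chlorine on the same aromatic carbon would match trifluoromethyl remains open, so it cannot yet be said whether this step is particular to that group. Also open, going by these compounds, is whether the same step would hold with a longer chain between the shared core and the aromatic ring that carries the change, or with a carboxylic acid or an amine in place of trifluoromethyl.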